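The source may report more compounds than this note shows. Statements on the series, on what has been measured and on what is new or still open speak of the compounds shown alone.

Measured so far:
compound 1, `CCCC(=O)OCC1CN(C(=O)c2cc(OC)c(OC)c(OC)c2)CCN1C(=O)c1cc(OC)c(OC)c(OC)c1`: 420 nM
compound 2, `CCCCCC(=O)OCC1CN(C(=O)c2cc(OC)c(OC)c(OC)c2)CCN1C(=O)c1cc(OC)c(OC)c(OC)c1`: 290 nM

In a functional assay (Oryctolagus cuniculus) for inhibition of platelet-activating factor receptor (Cavia porcellus) (on this read-out lower numbers stand for stronger inhibition and higher numbers for weaker inhibition), compound 2 gives 290 nM, and compound 1 differs from it only within the scatter, so neither of the two stands apart. Compound 3, `CCCCCCCC(=O)OCC1CN(C(=O)c2cc(OC)c(OC)c(OC)c2)CCN1C(=O)c1cc(OC)c(OC)c(OC)c1`, carries the change (ethyl in place of hydrogen on a saturated chain carbon, five bonds along the chain from a carbonyl carbon). Among the measured compounds shown here, the only measured step that bears on it is a 1.4-fold lower number from compound 1 to compound 2 (0.16 log units; within the scatter), which lengthened the same ester chain in the same way and stayed within the scatter. For compound 3 no shift beyond the scatter is therefore expected in this assay, only a step of about a 1.2-fold lower number from compound 2 to compound 3 (0.08 log units; within the scatter). Compound 3 is estimated at 240 nM, with a range from 110 nM to 520 nM.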

Compound 3, half-maximal inhibitory concentration: 310 nM
The estimate for compound 3 lay 1.3-fold (0.11 log units) below the measured number; the range from low to high includes it.
By their numbers in this assay, from the lowest: compounds 2, 3 and 1 (each within the scatter of the next).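

In this assay, ethyl in place of hydrogen on a saturated chain carbon, five bonds along the chain from a carbonyl carbon, gives a 1.1-fold higher number from compound 2 to compound 3 (0.03 log units; within the scatter) and the larger change to butyl gives a 1.4-fold lower number from compound 1 to compound 3 (0.13 log units; within the scatter) in the same sentence of numbers. Across these three compounds, the ester chain thus takes on added carbons with no step beyond the scatter, even over the larger change. Nothing measured here accounts for this. The compounds shown leave open whether a longer chain, or an amine or a carboxylic acid in place of this ester chain, would shift the number beyond the scatter.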